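The source may hold more compounds than are shown below. What is called first, only, known or untested is meant among the compounds shown, and "the series" means these compounds.

Working notes on the series built on the shared core, read in a physicochemical assay, read by spectrophotometry, with a stated time of 30 min; on this read-out higher numbers stand for weaker inhibition and lower numbers for stronger inhibition. Compound 1 (`O=C(CCc1nc2ccccc2c(=O)[nH]1)N/N=C/c1ccc(O)c(O)c1`) gives 113000000 nM, compound 2 (`O=C(CCc1nc2ccccc2c(=O)[nH]1)N/N=C/c1ccc([N+](=O)[O-])cc1`) gives 328000000 nM and compound 3 (`O=C(CCc1nc2ccccc2c(=O)[nH]1)N/N=C/c1ccc(Cl)cc1`) gives 381000000 nM. Compound 3 thus sits level with compound 2 within the scatter, and both lie well above compound 1, meaning weaker inhibition. Next comes compound 4 (`O=C(CCc1nc2ccccc2c(=O)[nH]1)N/N=C/c1ccccc1`), with the change hydrogen in place of chloro on an aromatic carbon. The closest measured step is a 1.2-fold higher number from compound 2 to compound 3 (0.07 log units; within the scatter), which also swaps one group on an aromatic carbon and stays within the scatter. The larger steps, a 2.9-fold higher number from compound 1 to compound 2 (0.46 log units; beyond the scatter) and a 3.4-fold higher number from compound 1 to compound 3 (0.53 log units; beyond the scatter), both start from the 3,4-dihydroxyphenyl of compound 1, which compound 4 does not carry. Within the data shown here, no measured step leads to the plain phenyl, so the read-across is limited. For compound 4 the estimated step is a 1.2-fold lower number from compound 3 to compound 4 (0.08 log units; within the scatter), so nothing beyond the scatter is expected in this assay. Compound 4 is expected at 320000000 nM, with an estimated range of 150000000 nM to 600000000 nM.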

Compound 4, half-maximal inhibitory concentration: 734000000 nM
Beside the measured number, compound 4's estimate is 2.3-fold (0.36 log units) below it; measured number above the stated range.
By their numbers in this assay, from the lowest: compound 1; then compounds 2, 3 and 4 (each within the scatter of the next, the first and the last beyond it).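

In this assay, removing the group para to a large group separates hydrogen from only one of the two substituents: a 1.9-fold higher number from compound 3 to compound 4 (0.28 log units; within the scatter) leaves chloro and hydrogen unresolved, whereas a 2.2-fold higher number from compound 2 to compound 4 (0.35 log units; beyond the scatter) shows that nitro gives modestly stronger inhibition than hydrogen at this place. The plain phenyl also gives the widest gap from the 3,4-dihydroxyphenyl of compound 1 in the series, with a 6.5-fold higher number from compound 1 to compound 4 (0.81 log units; beyond the scatter), though the step remains modest. Nothing available bears on the reason for these steps.

Going by these compounds, whether an amine or a carboxylic acid on the same aromatic carbon would give a lower number than nitro remains open. Also open, on these data alone, is whether a single hydroxy group would retain any of the advantage of compound 1 over compound 4.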